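This account rests on a few compounds, and the source may have more. Where it says the series, first, only, none or still open, it means among the compounds named here.

In an assay on cells for inhibition of interleukin-5 receptor subunit alpha (Mus musculus), read by WST assay, with a stated time of 48 h, in the presence of a further agent that is not named here (a lower number here means a stronger inhibitor, a higher number a weaker inhibitor), compound 1, `OCCNCc1nc2c(OCC3CCCCC3)cccc2[nH]1`, gives 20000 nM. Compound 2, `CCC(CO)NCc1nc2c(OCC3CCCCC3)cccc2[nH]1`, differs from it by an ethyl in place of hydrogen on a saturated chain carbon bound to an amine nitrogen and a saturated chain carbon, and in this assay compound 2 gives 3500 nM. For the measured compounds named here, that change brought a 5.7-fold lower number from compound 1 to compound 2 (0.76 log units; beyond the scatter), so compound 2 holds the lowest of the two numbers measured so far, with compound 1 as its only neighbour.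

Compound 3, `CCCC(CO)NCc1nc2c(OCC3CCCCC3)cccc2[nH]1`, carries the difference (methyl in place of hydrogen on a saturated chain carbon, three bonds along the chain from an amine nitrogen); read one bond further out, this is the ethyl of compound 2 becoming a propyl. Going by the values given here, the only step that bears on it is the one from compound 1 to compound 2, a modest lowering when the chain at that carbon was first built up. Lengthening it by one more carbon, further from the amine nitrogen, is expected to give a smaller step, if any, in the same direction. Compound 3 is therefore expected to show a 1.4-fold lower number from compound 2 to compound 3 (0.15 log units; within the scatter), a change that may not exceed the scatter. The estimate for compound 3 is 2500 nM, with a range from 900 nM to 7000 nM.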

Compound 3, half-maximal inhibitory concentration: 7500 nM
The estimate for compound 3 lay 3.0-fold (0.48 log units) below the measured number; measured number above the stated range.
By their numbers in this assay, from the lowest: compound 2; then compound 3; then compound 1.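

In this assay, the added length at this carbon does not keep lowering the number: going from ethyl to propyl reverses the direction of the earlier step, with a 2.1-fold higher number from compound 2 to compound 3 (0.33 log units; beyond the scatter), so the methyl added three bonds along the chain from an amine nitrogen gives back part of what the ethyl had gained. The propyl is still better than hydrogen at the saturated chain carbon bound to an amine nitrogen and a saturated chain carbon, with a 2.7-fold lower number from compound 1 to compound 3 (0.43 log units; beyond the scatter), but that gain is smaller than a 5.7-fold lower number from compound 1 to compound 2 (0.76 log units; beyond the scatter) seen with ethyl, which makes the ethyl of compound 2 the best of these three chains. Nothing available here accounts for this turn in the series.

As far as these compounds go, with only hydrogen, ethyl and propyl at this carbon, it remains open whether a methyl would already give part of the gain and whether a butyl would raise the number further. From the compounds shown here alone, it is also open whether a branched isopropyl or a cyclopropyl at the same carbon could match or improve on the ethyl.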